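This account rests on a few compounds, and the source may have more. Where it says the series, first, only, none or still open, it means among the compounds named here.

Two compounds of this series have numbers in an in vivo ADME assay on the whole organism (strain Sprague-Dawley) for metabolic stability, with Rattus norvegicus as the target, at a dose of 2 mg/kg by the intravenous route (a lower number here means that the compound disappears faster, a higher number that the compound lasts longer), so far. Compound 1 `Cc1c(F)cc(C(=O)NC2CC2)cc1-c1cc2cnnc(-c3ccc(F)cc3F)c2n(C)c1=O` gives 4.66 h in this assay. Compound 2 `Cc1cnc(C(=O)NC2CC2)cc1-c1cc2cnnc(-c3ccccc3C)c2n(C)c1=O` gives 2.15 h in this assay, the lowest of the two numbers; the nearest number is that of compound 1, which stands higher than compound 2 by a margin beyond the scatter. Compound 1 and compound 2 differ in more than one place, so no single step can be read from this pair; only the two values themselves are known.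

Compound 3 `Cc1cnc(C(=O)NC2CC2)cc1-c1cc2cnnc(-c3ccc(F)cc3C)c2n(C)c1=O` has not yet been measured in this assay. It differs from compound 2 in one place: fluoro in place of hydrogen on an aromatic carbon. Among the compounds with values here, no measured pair shows this change on its own, so no measured step sets its size. The expectation rests on compound 2 alone, with 2.15 h as the starting point. The step from compound 2 to compound 3 is expected to be small, a 1.2-fold higher number from compound 2 to compound 3 (0.08 log units; within the scatter), within the scatter or slightly toward a longer half-life. Compound 3 is expected to give 2.6 h in this assay, in the range 1.3 h to 5.2 h.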

Compound 3, half-life: 3.35 h
For compound 3 the middle estimate is 1.3-fold (0.11 log units) below the measured one; the range from low to high includes it.
By their numbers in this assay, from the lowest: compounds 2, 3 and 1 (each within the scatter of the next, the first and the last beyond it).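

The 2-methylphenyl to 4-fluoro-2-methylphenyl change gives the series its first single-place step in this assay and that step is a 1.6-fold higher number from compound 2 to compound 3 (0.19 log units; within the scatter), so on this background, fluoro on the aromatic carbon meta to a methyl group and para to a large group does not separate compound 3 from compound 2 by more than the scatter. This is one pair, and it sets no rule for fluoro on other backgrounds in the series. No measurement shown bears on what lies behind this result.

Still open, on these data alone, is whether a chloro, methoxy, nitrile or amine group on the same aromatic carbon would give a step beyond the scatter, or whether these groups would stay within it as fluoro does here. Within the data shown here, also open is whether fluoro in place of hydrogen at this position gives a step of similar size when other parts of the molecule differ, since only the pair of compound 2 and compound 3 isolates this change so far.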